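The source may report more compounds than this note shows. Statements on the series, on what has been measured and on what is new or still open speak of the compounds shown alone.

Measured in an assay on isolated protein for agonist activity at Bile acid receptor (Homo sapiens), read by FRET; a lower number here means that less compound is needed, a higher number that more compound is needed for the effect:
Compound 1 `O=C(O)c1cccc([C@H]2C[C@@H](c3ccc(OCc4c(-c5c(Cl)cccc5Cl)noc4C4CC4)cc3Cl)C2)c1` gives 77 nM.
Compound 2 `O=C(O)c1cncc(N2CC(O)(c3ccc(OCc4c(-c5c(Cl)cccc5Cl)noc4C4CC4)cc3Cl)C2)c1` gives 7 nM.
Compound 3 `O=C(O)c1cncc(C2CC2c2ccc(OCc3c(-c4c(Cl)cccc4Cl)noc3C3CC3)cc2Cl)c1` gives 10 nM.

Of the three numbers, compound 1 stands highest. Compound 3 sits at a lower number, and compound 2 at a lower one still; both gaps lie beyond the usual scatter, and neither pair differs from compound 1 in only one place, so no single-change step can be read from them.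

Compound 4 `CO[C@]1(c2ccc(OCc3c(-c4c(Cl)cccc4Cl)noc3C3CC3)cc2Cl)C[C@H](c2cccc(C(=O)O)c2)C1` is the untested partner of compound 1. It carries methoxy in place of hydrogen on a saturated ring carbon, a methoxy in place of hydrogen on a saturated ring carbon, with the rest of the shared core unchanged. Among the measured compounds shown here, no measured pair shows this exact change, so the size of the step rests on judgement alone. Compound 2, which bears an oxygen substituent on a ring carbon of its own, gives the lowest number in this assay, but it also differs from compound 1 in its ring and its acid-bearing group, so it offers only a loose hint rather than a measured step. The expectation for compound 4 is therefore a step of a 1.9-fold lower number from compound 1 to compound 4 (0.28 log units; within the scatter) that is modest and towards a lower number, with a real chance that it remains within the scatter. Compound 4 is estimated at 40 nM, in a range from 10 nM to 150 nM.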

Compound 4, half-maximal effective concentration: 79 nM
For compound 4 the middle estimate is 2.0-fold (0.30 log units) below the measured one, within the range that was stated.
By their numbers in this assay, from the lowest: compounds 2 and 3 (each within the scatter of the next); then compounds 1 and 4 (each within the scatter of the next).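

In this assay, a methoxy in place of hydrogen on a saturated ring carbon of the four-membered non-aromatic ring of carbon only gives a 1.0-fold higher number from compound 1 to compound 4 (0.01 log units; within the scatter) and so leaves the number where it was, as far as the scatter allows. Among the compounds shown here, this is the first step in the set that can be read from a single change, since none of the earlier compounds differed from one another in only one place: at this position, two ring bonds from the ring atom that bears the 3-carboxyphenyl group, the added methoxy neither raises nor lowers the number beyond the scatter. Nothing at hand gives a reason for this result.

Still open, from the compounds shown here alone, is whether another group on the same ring carbon of the core of compound 1 would read the same way, such as a hydroxyl, an amine or a longer chain like ethoxy. Also open, going by these compounds, is whether a methoxy would leave the number just as unmoved on the core of compound 2, or with the opposite spatial arrangement at this ring carbon.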